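Methyl for methoxy on the amide aryl group

The compounds below may be only part of what the source reports. "The series", "measured", "known", "first", "only" and "open" are said of these compounds alone.

The three measured compounds share one core and differ only in the aryl group attached to the amide carbonyl. In a functional assay on MCF7 cells (Homo sapiens) for antiproliferative activity, read by CCK-8 assay, with a stated time of 72 h (on this read-out lower numbers stand for stronger inhibition and higher numbers for weaker inhibition), compound 1 `O=C(Nc1cccc(-c2oc3cc(-c4ccc(F)cc4)ccc3c(=O)c2O)c1)c1ccc(F)cc1` gives 8590 nM, compound 2 `COc1ccccc1C(=O)Nc1cccc(-c2oc3cc(-c4ccc(F)cc4)ccc3c(=O)c2O)c1` gives 2100 nM, and compound 3 `COc1cccc(C(=O)Nc2cccc(-c3oc4cc(-c5ccc(F)cc5)ccc4c(=O)c3O)c2)c1` gives 15300 nM. Compound 3 sits at the high end of these numbers: its gap to compound 1, a 1.8-fold higher number from compound 1 to compound 3 (0.25 log units; within the scatter), is within the scatter, while a 7.3-fold higher number from compound 2 to compound 3 (0.86 log units; beyond the scatter) lies beyond it. Compound 4 `Cc1cccc(C(=O)Nc2cccc(-c3oc4cc(-c5ccc(F)cc5)ccc4c(=O)c3O)c2)c1` differs from compound 3 by methyl in place of methoxy on an aromatic carbon. For the measured compounds named here, no measured step exchanges methoxy for methyl; the steps in hand, a 4.1-fold lower number from compound 1 to compound 2 (0.61 log units; beyond the scatter) and a 1.8-fold higher number from compound 1 to compound 3 (0.25 log units; within the scatter), show only that a change of substituent on this aryl ring moves this assay by a modest amount or not beyond the scatter. The expected result for compound 4 is therefore a step of a 1.0-fold lower number from compound 3 to compound 4 (0.01 log units; within the scatter), within the scatter, with no direction favoured. Compound 4 is estimated at 15000 nM, with a range of 6000 nM to 35000 nM.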

Compound 4, half-maximal inhibitory concentration: 7850 nM
The estimate for compound 4 lay 1.9-fold (0.28 log units) above the measured number, and the stated range covers the measured number.
By their numbers in this assay, from the lowest: compound 2; then compounds 4, 1 and 3 (each within the scatter of the next).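

In this assay, for the compounds shown here, the first direct exchange at this position, 3-methylphenyl in place of 3-methoxyphenyl, gives a 1.9-fold lower number from compound 3 to compound 4 (0.29 log units; within the scatter), so replacing methoxy with methyl on this ring does not move the result beyond the scatter. The 3-methylphenyl group also stays within the scatter of 4-fluorophenyl, with a 1.1-fold lower number from compound 1 to compound 4 (0.04 log units; within the scatter), while the 2-methoxyphenyl group of compound 2 remains apart from all three others, as a 3.7-fold higher number from compound 2 to compound 4 (0.57 log units; beyond the scatter) also shows. No measurement at hand accounts for these steps.

On these data alone, whether methyl in place of methoxy would also leave the result of compound 2 within the scatter remains open. So does whether an amine or a carboxylic acid in place of this methyl would shift this assay beyond the scatter.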